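Working notes: from compound 2 to compound 3

The source may hold more compounds than are shown below. What is called first, only, known or untested is meant among the compounds shown, and "the series" means these compounds.

Measured in a functional assay on HL-60 cells (Homo sapiens) for inhibition, read by MTT assay, with a stated time of 48 h, tested at 10 uM; a lower number here means less inhibition of growth, a higher number more inhibition of growth at the concentration tested:
- compound 1 `Cc1cc(=O)c2c(O)cc(OCc3ccco3)c([C@H]3CCN(C)C[C@H]3O)c2o1`: 32%
- compound 2 `Cc1cc(=O)c2c(O)c(CN3CCCC3CO)c(O)c([C@H]3CCN(C)C[C@H]3O)c2o1`: 33%

Compound 2 stands level with compound 1, the two values lying within the scatter of each other. For the measured compounds named here, the two compounds differ in more than one place, so no single-change step is available, and neither value shows what a change of the amine alone does.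

Compound 3 `Cc1cc(=O)c2c(O)c(CN(C(C)C)C(C)C)c(O)c([C@H]3CCN(C)C[C@H]3O)c2o1` has not yet been measured. It carries diisopropylamino in place of 2-(hydroxymethyl)pyrrolidin-1-yl on a saturated chain carbon bound to an aromatic carbon.

The data give no direction for this change, so the expectation rests on compound 2 at 33% as the closest measured neighbour. No step beyond the scatter is expected, though the range is kept wide given how little supports it. The estimated step is a number 3 percentage points lower from compound 2 to compound 3 (within the scatter). For compound 3 the expected value in this assay is 30%, with an estimated range of 14% to 50%.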

Compound 3, percent growth inhibition at one concentration: 21%
For compound 3 the middle estimate is 9 percentage points above the measured one; low and high end bracket the measured number.
By their numbers in this assay, from the lowest: compound 3; then compounds 1 and 2 (each within the scatter of the next).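

In this assay, the series now has its first single-change step: diisopropylamino in place of 2-(hydroxymethyl)pyrrolidin-1-yl on a saturated chain carbon bound to an aromatic carbon gives a number 12 percentage points lower from compound 2 to compound 3 (beyond the scatter). This shows that the choice of amine at this place can alter growth inhibition at the concentration tested, which compound 1 and compound 2 could not show, as they differ in more than one place. The change replaces a ring-bearing group with a ring-free one and removes a hydrogen-bond donor, and no supporting data tie the step to either difference or to any other cause.

Still open, from the compounds shown here alone, is which part of the change carries the step; plain pyrrolidin-1-yl would separate the ring from the hydroxymethyl, and an open-chain amine bearing a hydroxyl, such as bis(2-hydroxyethyl)amino, would test the hydroxyl without the ring. Also open, going by these compounds, is whether the step extends beyond this one pair, including to other amines such as morpholin-4-yl or dimethylamino at this place.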